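Methyl in place of chloro in a small cell-tolerance series

The source may hold more compounds than are shown below. What is called first, only, known or untested is meant among the compounds shown, and "the series" means these compounds.

Compound 1 `COc1ccc(-c2cc(NC(=O)c3ccc(C)cc3O)c[nH]c2=O)cc1` gives 46100 nM
Compound 2 `Cc1cccc(-c2cc(NC(=O)c3ccccc3O)c[nH]c2=O)c1` gives 98800 nM
Compound 3 `Cc1cccc(-c2cc(NC(=O)c3ccc(Cl)cc3O)c[nH]c2=O)c1` gives 33100 nM

All three numbers come from an ADME assay on HepG2 2.2.15 cells (Homo sapiens) for cytotoxicity, read by CCK-8 assay, with a stated time of 8 days (a lower number here means that less compound is tolerated, a higher number that more compound is tolerated), and describe how much compound the cells tolerate. Compound 3 stands clearly under compound 2 and level, within the scatter, with compound 1.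

The next compound to be tested is compound 4 `Cc1cccc(-c2cc(NC(=O)c3ccc(C)cc3O)c[nH]c2=O)c1` and it differs from compound 3 by one small exchange: methyl in place of chloro on an aromatic carbon.

Going by the values given here, one measured step bears on this place directly: a 3.0-fold lower number from compound 2 to compound 3 (0.47 log units; beyond the scatter) is a modest step, seen when chloro replaced hydrogen on the same carbon. It shows that this position can move the number, but it says nothing about methyl. Some indirect help comes from compound 1, which carries the same 2-hydroxy-4-methylphenyl group on a different core and gives 46100 nM in this assay as its value. The expectation is therefore a small rise from compound 3, probably not beyond the scatter, and a value that stays under that of compound 2.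

The estimated change is a 1.5-fold higher number from compound 3 to compound 4 (0.18 log units; within the scatter) in size.

For compound 4 the expected value is 50000 nM with an estimated range from 25000 nM to 100000 nM as its span.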

Compound 4, half-maximal cytotoxic concentration: 75000 nM
For compound 4 the middle estimate is 1.5-fold (0.18 log units) below the measured one, within the range that was stated.
By their numbers in this assay, from the lowest: compounds 3, 1, 4 and 2 (each within the scatter of the next, the first and the last beyond it).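

Chloro and methyl each count as one heavy atom with no hydrogen-bond donors or acceptors, yet they are not interchangeable on this aromatic carbon: in this assay the exchange gives a 2.3-fold higher number from compound 3 to compound 4 (0.36 log units; beyond the scatter). Methyl on the same carbon cannot be told apart from hydrogen, with a 1.3-fold lower number from compound 2 to compound 4 (0.12 log units; within the scatter), so of the two groups seen here only chloro separates clearly from the unsubstituted compound 2. With the 2-hydroxy-4-methylphenyl group held fixed, placing 3-methylphenyl on the core instead of 4-methoxyphenyl gives a 1.6-fold higher number from compound 1 to compound 4 (0.21 log units; within the scatter), so this pair shows no clear shift from that other place.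

Nothing available here gives a reason for the gap between chloro and methyl. Going by these compounds, it also remains open where a fluoro group, an amine or a carboxylic acid on this carbon would fall relative to chloro and methyl, and whether the chloro-methyl gap would hold with 4-methoxyphenyl on the core.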